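Swapping phenyl for 3,4-difluorophenyl on the sulfonyl

A few compounds are considered here, and "the series" means these few. Any claim that something is new, unique, unknown or untested is made for them only; others in the source may bear on it.

Measured so far:
Compound 1, `CC1CCN(c2c(S(=O)(=O)c3ccccc3)cnc3cc(Cl)ccc23)CC1`: 93%
Compound 2, `CC1CCN(c2c(S(=O)(=O)c3cc(F)cc(F)c3)cnc3cc(F)ccc23)CC1`: 77%
Compound 3, `CC1CCN(c2c(S(=O)(=O)c3ccccc3)cnc3ccccc23)CC1`: 89.2%

In an assay on isolated protein for displacement of a labelled ligand from metabotropic glutamate receptor 5 (Homo sapiens), with a stated time of 60 min, tested at 1 uM (on this read-out higher numbers stand for more inhibition at the one concentration tested (going by the name of the read-out) and lower numbers for less inhibition), compound 1 gives the highest of the three numbers. Compound 3 lies nearest, and the step of a number 3.8 percentage points lower from compound 1 to compound 3 (within the scatter) stays within the scatter. Compound 2 lies furthest, with a gap beyond the scatter.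

Compound 4, `CC1CCN(c2c(S(=O)(=O)c3ccc(F)c(F)c3)cnc3cc(Cl)ccc23)CC1`, differs from compound 1 in one place: 3,4-difluorophenyl in place of phenyl on a sulfonyl sulfur. Among the measured compounds shown here, no measured step covers exactly this change. For the measured compounds named here, the only single-place step, a number 3.8 percentage points lower from compound 1 to compound 3 (within the scatter), concerns the chloro and was within the scatter. Compound 2 carries two fluorines on the sulfonyl-bound ring, though with a different fluoro pattern and fluoro in place of chloro, and gives the lowest value. A modest downward step is therefore expected, a number 8 percentage points lower from compound 1 to compound 4 (within the scatter). For compound 4 the estimate in this assay is 85%, ranging from 70% to 95%.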

Compound 4, a percentage reported as inhibition, at one concentration (the size of the read-out at that concentration, not a potency): 90%
Compound 4: middle estimate off by 5 percentage points, on the low side; low and high end bracket the measured number.
By their numbers in this assay, from the lowest: compound 2; then compounds 3, 4 and 1 (each within the scatter of the next).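

Replacing phenyl with 3,4-difluorophenyl on the sulfonyl sulfur gives a number 3 percentage points lower from compound 1 to compound 4 (within the scatter) in this assay. Among the compounds shown here, this is the first single-place reading at this position, and it shows that the ring on the sulfonyl sulfur can carry these two fluorines without a step beyond the scatter. Compound 2 could not show this, as it differs from compound 1 in more than one place. No available measurement gives a reason for this result.

As far as these compounds go, whether a methoxy group or an amine on this ring, or a longer alkyl chain in its place, would keep the number in this range remains open.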